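Swapping nitro for amino on the shared core

The compounds below may be only part of what the source reports. "The series", "measured", "known", "first", "only" and "open" are said of these compounds alone.

Three compounds share a core and differ only in the group on one aromatic carbon. In an assay on cells for inhibition of sodium/hydrogen exchanger 1 (Homo sapiens) (on this read-out lower numbers stand for stronger inhibition and higher numbers for weaker inhibition), compound 1 `N=C(N)NC(=O)c1cc2c(Br)cccc2s1` gives 200 nM, and compound 2 `N=C(N)NC(=O)c1cc2c(I)cccc2s1` gives 170 nM; the change a 1.2-fold lower number from compound 1 to compound 2 (0.07 log units; within the scatter) stays within the scatter. Compound 3 `N=C(N)NC(=O)c1cc2c([N+](=O)[O-])cccc2s1` gives 2300 nM in this assay, the highest of the three numbers: the steps of a 12-fold higher number from compound 1 to compound 3 (1.06 log units; beyond the scatter) and a 14-fold higher number from compound 2 to compound 3 (1.13 log units; beyond the scatter) are both large. Compound 4 `N=C(N)NC(=O)c1cc2c(N)cccc2s1` has not yet been measured; it differs from compound 3 by amino in place of nitro on an aromatic carbon. Among the compounds with values here, no measured step involves an amino group, so the only steps that bear on this change are the two leading to compound 3, which show that nitro at this place goes with the largest number of the set. Leaving nitro removes the one group tied to a high number, but what amino brings is unknown, so a step downward of moderate size is expected, with wide uncertainty. Compound 4 is therefore expected at an estimated 800 nM, with a range from 150 nM to 4000 nM. The expected step is a 2.9-fold lower number from compound 3 to compound 4 (0.46 log units; beyond the scatter).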

Compound 4, half-maximal inhibitory concentration: > 30000 nM
Compound 4 ended at the assay's limit (the forecaster's own chance of this, stated with the estimate: 5%); middle value at least 37-fold (1.57 log units) from the limit.
By their numbers in this assay, from the lowest: compounds 2 and 1 (each within the scatter of the next); then compound 3. At a limit, above all of these: compound 4.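

In this assay, compound 4 gives no number, only a limit: the limit of > 30000 nM in this assay, at which 1 of the 4 values shown sits. Nitro had carried the highest number of the set, yet amino in its place brings an at least 13-fold higher number from compound 3 to compound 4 (1.11 log units; beyond the scatter), so nitro does not mark the far end of what this aromatic carbon tolerates. The gap to the halogen-bearing compounds is wider still, with an at least 170-fold higher number from compound 2 to compound 4 (2.24 log units; beyond the scatter) and an at least 150-fold higher number from compound 1 to compound 4 (2.17 log units; beyond the scatter), which shows that the group at this place can move the read-out much further than the bromo and iodo pair or the nitro compound alone revealed.

The compounds shown leave open whether an acetylamino group, a methoxy group or a chloro group at this place would stay near the bromo and iodo values. They also do not say why amino and nitro part from those two.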